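The source may hold more compounds than are shown below. What is called first, only, known or untested is meant among the compounds shown, and "the series" means these compounds.

Among the measured compounds shown here, in a physicochemical assay for lipophilicity, read by HPLC, at pH 7.4 (on this read-out higher numbers stand for higher lipophilicity and lower numbers for lower lipophilicity), three compounds that share one core have numbers so far. Compound 1 `CNCc1cn(S(=O)(=O)c2cccnc2Cl)c(-c2cccnc2F)c1F` gives 0.75, compound 2 `CNCc1cn(S(=O)(=O)c2cccnc2C)c(-c2cccnc2F)c1F` gives 0.48, and compound 3 `CNCc1cn(S(=O)(=O)c2cnccc2C)c(-c2cccnc2F)c1F` gives 0.43. That leaves compound 3 level with compound 2 and under compound 1, as the modest step of a number 0.32 log units lower from compound 1 to compound 3 (beyond the scatter) shows.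

The next compound, compound 4 `CNCc1cn(S(=O)(=O)c2cncc(C)c2)c(-c2cccnc2F)c1F`, has no number yet. The change is 5-methylpyridin-3-yl in place of 4-methylpyridin-3-yl on a sulfonyl sulfur, which means 5-methylpyridin-3-yl in place of 4-methylpyridin-3-yl on a sulfonyl sulfur. The same atoms are simply joined differently.

For the measured compounds named here, the closest precedent is the swap of 2-methylpyridin-3-yl for 4-methylpyridin-3-yl, a number 0.05 log units lower from compound 2 to compound 3 (within the scatter). The exchange of chloro for methyl, a number 0.27 log units lower from compound 1 to compound 2 (within the scatter), is a different kind of change and says less here. On that precedent, no step beyond the scatter is expected in this assay, in either direction. The estimate amounts to an expected step of a number 0.03 log units higher from compound 3 to compound 4 (within the scatter). Compound 4 is estimated at 0.46, with an expected range of 0.2 to 0.72.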

Compound 4, distribution coefficient: 0.61
The estimate for compound 4 lay 0.15 log units below the measured number, and the stated range covers the measured number.
By their numbers in this assay, from the lowest: compounds 3, 2, 4 and 1 (each within the scatter of the next, the first and the last beyond it).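

In this assay, 5-methylpyridin-3-yl on the sulfonyl sulfur gives a number that cannot be separated from any earlier compound: the step is a number 0.18 log units higher from compound 3 to compound 4 (within the scatter) and a number 0.13 log units higher from compound 2 to compound 4 (within the scatter) and also a number 0.14 log units lower from compound 1 to compound 4 (within the scatter). The three methylpyridin-3-yl compounds therefore cannot be told apart here, so shifting the methyl around this ring has shown no effect larger than the scatter, while compound 4 also stays within the scatter of the chloro compound, compound 1. Nothing available gives a reason for these small differences.

Open, from the compounds shown here alone, is whether 5-chloropyridin-3-yl would match compound 4. It is also unknown whether a methoxy group, an amine or a carboxylic acid in place of that methyl would produce a step beyond the scatter.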